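Swapping an isobutyl for a naphthyl on a cytotoxicity core

The source may report more compounds than this note shows. Statements on the series, on what has been measured and on what is new or still open speak of the compounds shown alone.

Measured compounds:
Compound 1, `CC(C)Cc1ccc2c(NCCCNCc3ccco3)ccnc2c1`: 16000 nM
Compound 2, `COc1ccc(F)cc1CNCCCNc1ccnc2cc(CC(C)C)ccc12`: 2900 nM
Compound 3, `FC(F)(F)c1ccc(-c2ccc3c(NCCCNCc4ccco4)ccnc3c2)cc1`: 3470 nM

All three share one core and were tested in an ADME assay on HepG2 cells (Homo sapiens) for cytotoxicity, read by luminescence, CellTiter-Glo and ATP content, with a stated time of 72 h; on this read-out higher numbers stand for an effect only at larger amounts of compound and lower numbers for an effect already at smaller amounts. Compound 2 gives the lowest number of the three, but it lies within the scatter of compound 3, so the two cannot be ordered; compound 1 stands clearly apart, as the step of a 5.5-fold lower number from compound 1 to compound 2 (0.74 log units; beyond the scatter) shows.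

Compound 4, `COc1ccc(F)cc1CNCCCNc1ccnc2cc(-c3cccc4ccccc34)ccc12`, has not yet been measured. Its change from compound 2 is naphthalen-1-yl in place of isobutyl on an aromatic carbon. Going by the values given here, one measured step bears on this: a 4.6-fold lower number from compound 1 to compound 3 (0.66 log units; beyond the scatter), where an aromatic group likewise replaced isobutyl on an aromatic carbon of the shared core. That step was modest but beyond the scatter, toward a lower number. By analogy compound 4 is expected to show a step of similar direction and size, a 4.1-fold lower number from compound 2 to compound 4 (0.62 log units; beyond the scatter), with no certainty that a naphthalen-1-yl behaves like the group in compound 3.

The estimate for compound 4 in this assay is therefore 700 nM, with a range from 250 nM to 2500 nM.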

Compound 4, half-maximal effective concentration: 16000 nM
Compound 4: the middle estimate sits 23-fold (1.36 log units) below what was measured; measured number outside the range, above it.
By their numbers in this assay, from the lowest: compounds 2 and 3 (each within the scatter of the next); then compounds 1 and 4 (each within the scatter of the next).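

In this assay, putting naphthalen-1-yl in place of isobutyl at this position gives a 5.5-fold higher number from compound 2 to compound 4 (0.74 log units; beyond the scatter), whereas the earlier swap of isobutyl for an aromatic group gave a 4.6-fold lower number from compound 1 to compound 3 (0.66 log units; beyond the scatter). Replacing isobutyl with an aromatic group on this aromatic carbon therefore has no single direction across these two pairs: the number falls in one and rises in the other. The two pairs differ both in the aromatic group that enters and in the group at the end of the side chain, furan-2-yl in one and 5-fluoro-2-methoxyphenyl in the other, and no supporting measurement is available to explain the reversal.

The compounds shown leave open whether the reversal follows the entering group or the side chain, a question that naphthalen-1-yl paired with the furan-2-yl side chain, or 4-(trifluoromethyl)phenyl paired with the 5-fluoro-2-methoxyphenyl side chain, could help answer. Also open, from the compounds shown here alone, is how the number would respond to an amine, a carboxylic acid or a longer carbon chain on this same aromatic carbon.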